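The compounds below may be only part of what the source reports. "The series", "measured", "known", "first", "only" and "open" are said of these compounds alone.

Among the compounds with values here, in a functional assay on CCRF-CEM cells (Homo sapiens) (a lower number here means that less compound is tolerated, a higher number that more compound is tolerated), compound 2 `CCOC(=O)CNC(=O)NC1=CS(=O)(=O)O[C@@]12[C@@H](CO[Si](C)(C)C(C)(C)C)O[C@@H](n1cc(C)c(=O)n(C)c1=O)[C@@H]2O[Si](C)(C)C(C)(C)C` gives 5020 nM, the lowest of the three numbers known so far. Compound 1 `COC(=O)CC(=O)NC1=CS(=O)(=O)O[C@@]12[C@@H](CO[Si](C)(C)C(C)(C)C)O[C@@H](n1cc(C)c(=O)n(C)c1=O)[C@@H]2O[Si](C)(C)C(C)(C)C` gives 29700 nM, and compound 3 `Cc1cn([C@@H]2O[C@@H]3COC(=O)[C@]3(OS(C)(=O)=O)[C@H]2O)c(=O)[nH]c1=O` gives 160000 nM. Compound 4 `Cc1cn([C@@H]2O[C@H](CO[Si](C)(C)C(C)(C)C)[C@@]3(OS(=O)(=O)C=C3NC(=O)NC(=O)c3ccccc3)[C@H]2O[Si](C)(C)C(C)(C)C)c(=O)n(C)c1=O` has not yet been measured; it differs from compound 2 by benzoyl in place of (ethoxycarbonyl)methyl on an amide-type nitrogen. Within the data shown here, only one measured step touches this part of the molecule: a 5.9-fold lower number from compound 1 to compound 2 (0.77 log units; beyond the scatter), which shows that changing the group on this side chain can move the number beyond the scatter. Among the measured compounds shown here, no measured compound carries a benzoyl group, so the direction of the next step is open, and the step expected is a 1.3-fold lower number from compound 2 to compound 4 (0.10 log units; within the scatter). Compound 4 is therefore estimated at 4000 nM, with a likely range from 1000 nM to 16000 nM.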

Compound 4, half-maximal cytotoxic concentration: 2290 nM
For compound 4 the middle estimate is 1.7-fold (0.24 log units) above the measured one; the measured number falls inside the stated range.
By their numbers in this assay, from the lowest: compound 4; then compound 2; then compound 1; then compound 3.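

Placing benzoyl on the amide-type nitrogen lowers the number further in this assay (a 2.2-fold lower number from compound 2 to compound 4 (0.34 log units; beyond the scatter)), so this side chain still responds when (ethoxycarbonyl)methyl gives way to a group with a six-membered aromatic ring and no ester. Measured against the other side chain, the change is larger (a 13-fold lower number from compound 1 to compound 4 (1.11 log units; beyond the scatter)). Nothing measured here explains why the number falls.

From the compounds shown here alone, it remains open whether the aromatic ring matters or the carbonyl alone is enough, which an acetyl group on the same nitrogen would test. A cyclohexanecarbonyl group would separate the ring's aromatic character from its size.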